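The compounds below may be only part of what the source reports. "The series", "measured", "known", "first", "only" and "open" are said of these compounds alone.

Measured so far:
compound 1 `Nc1cc(N)c2nc(-c3ccccc3)c(Oc3ccc(Cl)c(Cl)c3)nc2c1` — < 100000 nM
compound 2 `CCOC(=O)[C@H](CCC(=O)O)NC(=O)c1ccc(CNc2nc3cc(N)cc(N)c3nc2-c2ccccc2)cc1` — < 100000 nM

Both measurements come from a functional assay on MCF7 cells (Homo sapiens) for inhibition, read by sulforhodamine B assay, with a stated time of 48 h; on this read-out lower numbers stand for higher toxicity in this test and higher numbers for lower toxicity in this test. In this assay compound 1 gives < 100000 nM, which is a limit of the assay and not a number. In this assay compound 2 gives < 100000 nM, again a limit rather than a number. Compound 1 therefore stands at the limit of < 100000 nM in this assay, at which 2 of the 2 values shown sit. Within the data shown here, no pair of measured compounds that differ in one place exists here, so no step between two real numbers is available to draw on.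

Compound 3 `Nc1cc(N)c2nc(-c3ccccc3)c(Sc3ccc(Cl)c(Cl)c3)nc2c1` has not yet been measured in this assay. It differs from compound 1 in one place: (3,4-dichlorophenyl)sulfanyl in place of 3,4-dichlorophenoxy on an aromatic carbon. Among the measured compounds shown here, with no measured step to guide the expectation, and only limits for the compounds that have been tested, the change from compound 1 to compound 3 is not expected to move the result beyond the usual scatter of this assay; the expected step is a step that the limit leaves unreadable from compound 1 to compound 3. For compound 3 the estimate in this assay is 30000 nM, with a range from 5000 nM to 100000 nM, and a real chance that only a limit is reported again.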

Compound 3, concentration lethal to 50% of the cells: < 100000 nM
Compound 3 was reported as a limit (the forecaster's own chance of this, stated with the estimate: 60%); the middle value is on the limit's open side.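

In this assay compound 3 gives < 100000 nM, which is a limit of the assay and not a number. Among these compounds, compound 1 also has only a limit, so no step between compound 1 and compound 3 can be read: the limit of < 100000 nM in this assay, at which 3 of the 3 values shown sit. The compounds shown leave open whether exchanging 3,4-dichlorophenoxy for (3,4-dichlorophenyl)sulfanyl alters the result at all.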